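A few compounds are considered here, and "the series" means these few. Any claim that something is new, unique, unknown or untested is made for them only; others in the source may bear on it.

Measured compounds in this series:

- compound 1, `Cc1ccc(OS(=O)(=O)c2ccc(N3CCN(C)C3=O)cc2)c(C)c1`: 2500 nM
- compound 2, `COc1cc(OC)cc(OS(=O)(=O)c2ccc(N3CCN(C)C3=O)cc2)c1`: 230 nM
- compound 3, `COc1cc(OS(=O)(=O)c2ccc(N3CCN(C)C3=O)cc2)cc(OC)c1OC`: 120 nM

All three share the same sulfonate ester core and differ only in the aryl group on the ester oxygen. In a functional assay on MCF7 cells (Homo sapiens) for antiproliferative activity, read by sulforhodamine B assay, with a stated time of 48 h (a lower number here means a stronger inhibitor, a higher number a weaker inhibitor), compound 1 gives 2500 nM, the highest number of the three. Compound 2 gives 230 nM and compound 3 gives 120 nM; both of these pairs with compound 1 lie well beyond the scatter, and the two methoxy-bearing compounds are separated from each other only by a 1.9-fold lower number from compound 2 to compound 3 (0.28 log units; within the scatter), which stays within the scatter.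

Compound 4, `CN1CCN(c2ccc(S(=O)(=O)Oc3ccc(Cl)cc3)cc2)C1=O`, is not yet measured. Relative to compound 1 the change is 4-chlorophenyl in place of 2,4-dimethylphenyl on an oxygen. Going by the values given here, no measured step involves a chlorine, and the single step on record, from compound 2 to compound 3, concerns a methoxy group on a different aryl pattern, so it bears only loosely on this change. What the values show is that the 2,4-dimethylphenyl ester of compound 1 sits far above the methoxy-substituted esters; a 4-chlorophenyl ester carries neither methyl nor methoxy groups, and no data here indicate which way it should move. The expected step is therefore a 1.3-fold lower number from compound 1 to compound 4 (0.10 log units; within the scatter), that is, none clearly beyond the scatter, with a wide range. Compound 4 is estimated at 2000 nM in this assay, between 500 nM and 8000 nM.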

Compound 4, half-maximal inhibitory concentration: > 100000 nM
Compound 4: a limit, no number; the forecaster's own chance of this, stated with the estimate: 10%; middle value at least 50-fold (1.69 log units) from the limit.
By their numbers in this assay, from the lowest: compounds 3 and 2 (each within the scatter of the next); then compound 1. At a limit, above all of these: compound 4.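

The earlier compounds shown here all gave numbers, so they showed this position only as a place where the aryl group shifts the value; the swap of 2,4-dimethylphenyl for 4-chlorophenyl on the oxygen shows that a single change here can take the series out of the measurable range, with an at least 40-fold higher number from compound 1 to compound 4 (1.60 log units; beyond the scatter). In this assay compound 4 gives > 100000 nM, which is a limit of the assay and not a number: the limit of > 100000 nM in this assay, at which 1 of the 4 values shown sits. The leaving and entering groups match in the counted features, each being one six-membered aromatic ring of carbon only, with no hydrogen-bond donors or acceptors and no net charge, so those counts do not separate a compound with a number from one at the limit.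

Since the change removes the methyl groups and brings in the chlorine in one step, the compounds shown leave open which of the two carries the step. Also open, as far as these compounds go, is how an aryl group bearing an amine or a carboxylic acid on this oxygen would read in this assay.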